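Benzylamine swap on the shared core: dichloro to fluoro

A few compounds are considered here, and "the series" means these few. Any claim that something is new, unique, unknown or untested is made for them only; others in the source may bear on it.

Working notes on the series. Compound 1 `Nc1cc(N)c2nc(-c3ccccc3)c(Oc3ccc(Cl)c(Cl)c3)nc2c1`, compound 2 `Nc1cc(N)c2nc(-c3ccccc3)c(NCc3ccc(Cl)c(Cl)c3)nc2c1` and compound 3 `CCOC(=O)[C@H](CCC(=O)O)NC(=O)c1ccc(Oc2nc3cc(N)cc(N)c3nc2-c2ccccc2)cc1` share one core and differ at the group attached to it. In a functional assay on A498 cells (Homo sapiens) for inhibition, read by sulforhodamine B assay, with a stated time of 48 h (on this read-out lower numbers stand for higher toxicity in this test and higher numbers for lower toxicity in this test), compound 2 gives 60300 nM. Compound 3 gives 33900 nM in this assay, and the two numbers lie within the scatter of each other, so no order between compound 2 and compound 3 is claimed. For compound 1 this assay reports only a limit, < 100000 nM; (the limit of < 100000 nM in this assay, at which 1 of the 3 values shown sits). Compound 2 thus carries the higher of the two actual numbers, with compound 3 close by.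

Compound 4 `Nc1cc(N)c2nc(-c3ccccc3)c(NCc3ccc(F)cc3)nc2c1` is not yet measured. It differs from compound 2 by 4-fluorophenyl in place of 3,4-dichlorophenyl on a saturated chain carbon bound to a nitrogen on an aromatic ring. Going by the values given here, no measured pair follows the same change, and nothing ties a step to this exchange. Given that compound 2 gives 60300 nM and all three measured compounds sit in the same weak range, the step from compound 2 to compound 4 is expected to stay within the scatter, with a slight lean toward a higher number. The expected step is a 1.2-fold higher number from compound 2 to compound 4 (0.09 log units; within the scatter). Compound 4 is estimated at 75000 nM in this assay, between 30000 nM and 180000 nM.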

Compound 4, concentration lethal to 50% of the cells: 57500 nM
Compound 4: middle estimate off by 1.3-fold (0.12 log units), on the high side; measured number inside the range.
By their numbers in this assay, from the lowest: compounds 3, 4 and 2 (each within the scatter of the next).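

In this assay, 4-fluorophenyl in place of 3,4-dichlorophenyl on a saturated chain carbon bound to a nitrogen on an aromatic ring gives a 1.0-fold lower number from compound 2 to compound 4 (0.02 log units; within the scatter). Going by these compounds alone, this is the first one-place step readable at this position, and it shows that the read-out does not separate the 3,4-dichlorobenzyl and 4-fluorobenzyl groups beyond the scatter. The step that starts from compound 1 cannot be read, since compound 1 carries only a limit: the limit of < 100000 nM in this assay, at which 1 of the 4 values shown sits.

With a single readable step, this position is tested only by two halogen-bearing phenyl groups, so no trend can be drawn from it. Going by these compounds, whether a carboxylic acid or an amine on that phenyl ring, or a longer chain in place of the benzyl carbon, would move the number remains open.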